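The compounds below may be only part of what the source reports. "The series", "measured", "known", "first", "only" and "open" are said of these compounds alone.

Measured so far:

compound 1 `N#C/N=C1\N(CCCCCOc2ccc(Cl)cc2)C(=O)CN1c1ccncc1` — 8970 nM
compound 2 `N#C/N=C1\N(CCCCCCOc2ccc(Cl)cc2)C(=O)CN1c1ccncc1` — 3860 nM
compound 3 `N#C/N=C1\N(CCCCCCCOc2ccc(Cl)cc2)C(=O)CN1c1ccncc1` — 3500 nM

These three compounds were tested in a functional assay on HA22T cells for cytotoxicity against HA22T cell line (Homo sapiens); a lower number here means a stronger inhibitor, a higher number a weaker inhibitor. Compound 3 has the lowest number of the three, but its step from compound 2 (a 1.1-fold lower number from compound 2 to compound 3 (0.04 log units; within the scatter)) lies within the scatter, so the two cannot be told apart, while a 2.6-fold lower number from compound 1 to compound 3 (0.41 log units; beyond the scatter) and a 2.3-fold lower number from compound 1 to compound 2 (0.37 log units; beyond the scatter) both lie beyond it. Every measured step alters only the chain that carries the 4-chlorophenoxy group.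

Compound 4 `CCC1C(=O)N(CCCCCCCOc2ccc(Cl)cc2)/C(=N\C#N)N1c1ccncc1` has not yet been measured. It differs from compound 3 by ethyl in place of hydrogen on a saturated ring carbon. Going by the values given here, no measured step touches this ring carbon; all three vary the chain, so nothing measured bears directly on this change. Among the compounds with values here, with no step pointing in either direction, the number for compound 4 is expected to stay close to that of compound 3. The step expected in this assay is no change at the digits printed from compound 3 to compound 4 (within the scatter), none beyond the scatter. Compound 4 is therefore estimated at 3500 nM, in a range from 1200 nM to 10000 nM.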

Compound 4, half-maximal inhibitory concentration: 6050 nM
Beside the measured number, compound 4's estimate is 1.7-fold (0.24 log units) below it; measured number inside the range.
By their numbers in this assay, from the lowest: compounds 3, 2, 4 and 1 (each within the scatter of the next, the first and the last beyond it).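

Going by these compounds alone, compound 4 gives the first reading at this position, the saturated ring carbon next to the ring nitrogen, where the earlier compounds carry only hydrogen. In this assay the change from hydrogen to ethyl gives a 1.7-fold higher number from compound 3 to compound 4 (0.24 log units; within the scatter) and, as that step lies within the scatter, compound 3 and compound 4 cannot be told apart, so adding these 2 carbons here has no effect that this assay can resolve. Nothing available explains this outcome or links it to any property of the ethyl group. On these data alone, a single substituent says little about the position as a whole, so it remains open whether a methyl, a phenyl or a carboxylic acid on this carbon would give a step beyond the scatter. As far as these compounds go, it is also open whether the ethyl group would give a similar result on the shorter chain of compound 1.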